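This account rests on a few compounds, and the source may have more. Where it says the series, first, only, none or still open, it means among the compounds named here.

In a functional assay on DU-145 cells (Homo sapiens) for inhibition, read by trypan blue exclusion, with a stated time of 96 h (a lower number here means a stronger inhibitor of growth, a higher number a weaker inhibitor of growth), compound 1 (`O=C(/C(=C\c1ccc(F)c([N+](=O)[O-])c1)S(=O)(=O)c1ccc(Br)cc1)c1ccc(Br)cc1`) gives 25000 nM and compound 2 (`O=C(/C(=C\c1ccc(Cl)cc1Cl)S(=O)(=O)c1ccc(Br)cc1)c1ccc(Br)cc1`) gives 10000 nM which is the lower of the two numbers and so marks compound 2 as the stronger inhibitor of growth. Within the data shown here, the only measured step is a 2.5-fold lower number from compound 1 to compound 2 (0.40 log units; beyond the scatter) and it is a modest one, made at the same place as the next change. Compound 3 (`O=C(/C(=C\c1ccc(I)cc1)S(=O)(=O)c1ccc(Br)cc1)c1ccc(Br)cc1`) carries 4-iodophenyl in place of 2,4-dichlorophenyl on a double-bonded chain carbon bound to a double-bonded chain carbon. Among the measured compounds shown here, no measured compound carries iodine, so the data give no clear direction, and the modest size of a 2.5-fold lower number from compound 1 to compound 2 (0.40 log units; beyond the scatter) is the only guide. In this assay no change beyond the scatter is expected, and the estimated step is a 1.2-fold higher number from compound 2 to compound 3 (0.08 log units; within the scatter) for now. Compound 3 is expected at 12000 nM with an estimated range of 4000 nM to 30000 nM around that figure.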

Compound 3, concentration for 50% growth inhibition: 1000 nM
For compound 3 the middle estimate is 12-fold (1.08 log units) above the measured one; the measured number lies below the stated range.
By their numbers in this assay, from the lowest: compound 3; then compound 2; then compound 1.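

In this assay, among these compounds, the group on a double-bonded chain carbon bound to a double-bonded chain carbon proves able to move the number much further than the earlier compounds showed: replacing 2,4-dichlorophenyl with 4-iodophenyl gives a 10-fold lower number from compound 2 to compound 3 (1.00 log units; beyond the scatter), and replacing 4-fluoro-3-nitrophenyl with it gives a 25-fold lower number from compound 1 to compound 3 (1.40 log units; beyond the scatter). Among the three groups seen at this place, 4-iodophenyl gives the lowest number, with both of its steps beyond the scatter. The step from 2,4-dichlorophenyl to 4-iodophenyl leaves the six-membered aromatic ring of carbon only and the count of hydrogen-bond donors and acceptors unchanged, and nothing available accounts for its size. These compounds do not separate the identity of the halogen from the number of halogens on the ring. From the compounds shown here alone, how 4-chlorophenyl, 4-bromophenyl or 4-aminophenyl would read at this place remains open.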